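The source may report more compounds than this note shows. Statements on the series, on what has been measured and on what is new or still open speak of the compounds shown alone.

Working notes on the series.

Two compounds have numbers in a functional assay on Z-138 cells (Homo sapiens) for inhibition, read by luminescence and CellTiter-Glo, with a stated time of 72 h; a higher number here means a weaker inhibitor, a lower number a stronger inhibitor. Compound 1 `C/C=C/C(=O)Nc1ccc(Cn2nc(-c3ccc(Oc4ccccc4)cc3)cc2C(=O)OCC)cc1` gives only a limit, > 60000 nM, and not a number. Among the measured compounds shown here, compound 2 `O=C(CCl)Nc1ccc(Cn2nc(-c3ccc(Oc4ccccc4)cc3)cc2C(=O)O)cc1` gives 1500 nM and stands as the only measured value in this assay. The other entry, that of compound 1, is a limit, and the limit of > 60000 nM in this assay, at which 1 of the 2 values shown sits, marks where it sits. For the measured compounds named here, no pair of measured compounds differs in a single place, so no measured step can be read from these two, and the gap between compound 1 and compound 2 covers more than one change at once.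

Compound 3 `CCOC(=O)c1cc(-c2ccc(Oc3ccccc3)cc2)nn1Cc1ccc(NC(=O)CCl)cc1` is not yet measured. It differs from compound 2 by ethyl in place of hydrogen on an oxygen next to a carbonyl group. Compound 1 also carries the ethoxycarbonyl, but its other change keeps its limit from speaking to this step alone.

Expectation for compound 3 in this assay: a loss of potency relative to compound 2, a step from compound 2 to compound 3 of a 4.0-fold higher number from compound 2 to compound 3 (0.60 log units; beyond the scatter), beyond the usual scatter, with the estimate resting on the ethyl in place of hydrogen that compound 1 shares. The estimate for compound 3 is 6000 nM, with a range from 1200 nM to 40000 nM.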

Compound 3, half-maximal inhibitory concentration: 400 nM
Compound 3: the middle estimate sits 15-fold (1.18 log units) above what was measured; the whole stated range lies above it.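

At this position the step is now read alone, with the chloromethyl amide unchanged: ethyl in place of hydrogen on an oxygen next to a carbonyl group gives a 3.8-fold lower number from compound 2 to compound 3 (0.57 log units; beyond the scatter) in this assay, so carboxy to ethoxycarbonyl runs towards a lower number and not a higher one. With ethoxycarbonyl held constant, chloromethyl in place of prop-1-en-1-yl on a carbonyl carbon gives an at least 150-fold lower number from compound 1 to compound 3 (2.17 log units; beyond the scatter), which places this large difference at that carbonyl substituent and not at the ester. That step rests on a limit and not on a number, as compound 1 gives only a limit: the limit of > 60000 nM in this assay, at which 1 of the 3 values shown sits.

As far as these compounds go, whether the trend on that oxygen extends past ethyl, to methyl or a longer chain, or to a primary amide in place of the ester, stays open. Also open, from the compounds shown here alone, is whether the carboxy to ethoxycarbonyl step keeps its direction with prop-1-en-1-yl or with a plain methyl on the amide carbonyl carbon in place of chloromethyl.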